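Adding a second trifluoromethyl group to a urea-linked analog

The compounds below may be only part of what the source reports. "The series", "measured", "known", "first", "only" and "open" are said of these compounds alone.

The account starts from compound 1 `O=C(Nc1cccc(-n2cc(-c3ccncc3)c(-c3ccc(Cl)c(O)c3)n2)c1)Nc1cccc(C(F)(F)F)c1`. In a functional assay on SK-OV-3 cells (Homo sapiens) for inhibition, read by sulforhodamine B assay, with a stated time of 48 h (on this read-out lower numbers stand for higher toxicity in this test and higher numbers for lower toxicity in this test), compound 1 gives > 32500 nM, which is a limit of the test rather than a number. Compound 3 `O=C(Nc1cccc(-n2cc(-c3ccncc3)c(-c3ccc(Cl)c(O)c3)n2)c1)Nc1ccc(Cl)c(Cl)c1` carries 3,4-dichlorophenyl in place of 3-(trifluoromethyl)phenyl on an amide-type nitrogen. In this assay compound 3 gives > 32500 nM, again a limit. The step that the two limits leave unreadable from compound 1 to compound 3 therefore cannot be read. Compound 2 `COc1cc(-c2nn(-c3cccc(NC(=O)c4cccc(C(F)(F)F)c4)c3)cc2-c2ccncc2)ccc1Cl`, which has a different linker and a methoxy in place of the hydroxyl, gives > 50000 nM in this assay, also a limit. Among the compounds with values here, all three values sit at limits, two at the limit of > 32500 nM in this assay, at which 2 of the 3 values shown sit, and one at the limit of > 50000 nM in this assay, at which 1 of the 3 values shown sits, so no step of readable size is available to guide the next change.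

Compound 4 `O=C(Nc1cccc(-n2cc(-c3ccncc3)c(-c3ccc(Cl)c(O)c3)n2)c1)Nc1cc(C(F)(F)F)cc(C(F)(F)F)c1` is drawn from compound 1 by the change (trifluoromethyl in place of hydrogen on an aromatic carbon). Within the data shown here, no measured step bears on it beyond the limits already named, so no change beyond the scatter is expected in this assay, and compound 4 is expected to remain at a limit: the estimate for compound 4 is 40000 nM, within 15000 nM to 100000 nM, meaning an expected step that the limit leaves unreadable from compound 1 to compound 4.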

Compound 4, concentration lethal to 50% of the cells: > 50000 nM
Compound 4: only a limit was reported; the forecaster's own chance of this, stated with the estimate: 85%; middle value at least 1.2-fold (0.09 log units) away from the limit.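

Compound 1 and compound 4 both stand at limits in this assay, so the step between them cannot be read. The compounds shown leave open whether trifluoromethyl in place of hydrogen on an aromatic carbon changes this read-out at all, since none gives a readable number.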